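Amino in Place of Chloro: What to Expect for Compound 4

A few compounds are considered here, and "the series" means these few. Any claim that something is new, unique, unknown or untested is made for them only; others in the source may bear on it.

Three compounds have been measured in a functional assay on U-937 cells (Homo sapiens) for cytotoxicity, read by MTT assay, with a stated time of 48 h; on this read-out lower numbers stand for stronger inhibition and higher numbers for weaker inhibition:

compound 1, `Fc1cccc(-c2nc(Nc3ccccc3)c3cc(F)ccc3n2)c1`, gives 45500 nM
compound 2, `Fc1cccc(-c2nc(Nc3ccc(Cl)cc3)c3cc(F)ccc3n2)c1`, gives 32700 nM
compound 3, `Fc1cccc(-c2nc(Nc3ccccc3Cl)c3cc(F)ccc3n2)c1`, reaches only the limit of > 50000 nM

Among the two plain numbers, compound 2 carries the lower one, with compound 1 nearest; the step of a 1.4-fold lower number from compound 1 to compound 2 (0.14 log units; within the scatter) lies within the scatter, so the two cannot be ranked. For compound 3 the value is a limit of this assay rather than a number, and the step of an at least 1.5-fold higher number from compound 2 to compound 3 (0.18 log units; that floor lies within the scatter) is a floor that also lies within the scatter.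

Compound 4, `Nc1ccc(Nc2nc(-c3cccc(F)c3)nc3ccc(F)cc23)cc1`, has not yet been measured. It differs from compound 2 by amino in place of chloro on an aromatic carbon. Among the measured compounds shown here, the one measured step at this same site is the step of a 1.4-fold lower number from compound 1 to compound 2 (0.14 log units; within the scatter), which shows that exchanging the group on this carbon moved the number only within the scatter. The step from chloro to amino is a different exchange, but nothing measured points to a large effect at this place. Compound 4 is therefore expected to sit close to compound 2, at an estimated 36000 nM, with a likely range from 14000 nM to 90000 nM, which amounts to an expected step of a 1.1-fold higher number from compound 2 to compound 4 (0.04 log units; within the scatter).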

Compound 4, half-maximal inhibitory concentration: > 50000 nM
Compound 4: a limit, no number; the forecaster's own chance of this, stated with the estimate: 30%; middle value at least 1.3-fold (0.14 log units) from the limit.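

In this assay compound 4 gives > 50000 nM, which is a limit and not a number. With amino, this carbon has now carried three groups, and amino, the only one of them with a hydrogen-bond donor, gives no sign of a lower number: the steps are an at least 1.5-fold higher number from compound 2 to compound 4 (0.18 log units; that floor lies within the scatter) and an at least 1.0-fold higher number from compound 1 to compound 4 (0.04 log units; that floor lies within the scatter), so neither separates amino from chloro or from hydrogen. How far compound 4 really lies from compound 2 cannot be told, because the read-out stops at a limit: the limit of > 50000 nM in this assay, at which 2 of the 4 values shown sit.

The step between the two limited compounds, compound 3 and compound 4, cannot be read, so the 4-aminophenyl and 2-chlorophenyl groups stay unranked. Going by these compounds, whether a carboxylic acid, a methoxy group or a longer chain on this carbon would give a number clearly apart from compound 2 remains open.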